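The source may report more compounds than this note shows. Statements on the series, on what has been measured and on what is new or still open speak of the compounds shown alone.

Measured compounds:

Compound 1, `O=C(CN(c1nc(Cl)nc2[nH]cnc12)C1CC1)N[C@@H](CO)C(=O)OCc1ccccc1`, gives 31.9% in a functional assay on the whole organism (Tail, strain ICR) with Mus musculus as the target, in the tail flick test, with a stated time of 30 min, at a dose of 25 umol/kg by the oral route; on this read-out lower numbers stand for a weaker effect and higher numbers for a stronger effect at the one dose given.
Compound 2, `NC(=O)CC[C@H](NC(=O)CN(c1ncnc2c1ncn2C1CCCCO1)C1CC1)C(=O)OCc1ccccc1`, gives 47%.
Compound 3, `O=C(CN(c1ncnc2c1ncn2C1CCCCO1)C1CC1)N[C@@H](CCC(=O)OCc1ccccc1)C(=O)OCc1ccccc1`, gives 32.6%.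

Compound 3 stands second highest of the three numbers. Its nearest neighbour is compound 1, whose value lies within the scatter of that of compound 3. Among the measured compounds shown here, the only value beyond the scatter is that of compound 2, and the one counted step, a number 14.4 percentage points lower from compound 2 to compound 3 (beyond the scatter), is modest and lies on the same side chain that is now in question.

Compound 4, `O=C(CN(c1ncnc2c1ncn2C1CCCCO1)C1CC1)NCC(=O)OCc1ccccc1`, differs from compound 3 in one place: hydrogen in place of 2-(benzyloxycarbonyl)ethyl on a saturated chain carbon bound to an amide-type nitrogen and a carbonyl carbon. For the measured compounds named here, no measured pair removes this chain outright; the step from compound 2 to compound 3 only exchanges the group on its carbonyl carbon, and compound 1 carries a different chain on a different core, so its value cannot be read as a step. The bearing of the measured step is therefore indirect: the tail has shown it can shift the read-out by a modest amount, and its removal is not expected to move the number beyond the scatter from compound 3 in either direction with any confidence. The expected step is a number 1.4 percentage points higher from compound 3 to compound 4 (within the scatter). Compound 4 is estimated at 34%, within 18% to 52%.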

Compound 4, a percentage reported as activity, at one dose (the size of the read-out at that dose, not a potency): 55.7%
Beside the measured number, compound 4's estimate is 21.7 percentage points below it; the whole stated range lies below it.
By their numbers in this assay, from the lowest: compounds 1 and 3 (each within the scatter of the next); then compounds 2 and 4 (each within the scatter of the next).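

In this assay, hydrogen in place of 2-(benzyloxycarbonyl)ethyl on the saturated chain carbon bound to an amide-type nitrogen and a carbonyl carbon gives a number 23.1 percentage points higher from compound 3 to compound 4 (beyond the scatter) and so shows that this position needs no side chain to keep the read-out. Hydrogen in place of 2-carbamoylethyl at the same carbon gives a number 8.7 percentage points higher from compound 2 to compound 4 (within the scatter) and so does not separate that chain from hydrogen, which leaves 2-(benzyloxycarbonyl)ethyl as the one group of the three set apart on this read-out. Nothing on hand accounts for this difference between the groups.

The compounds shown leave open whether a methyl group or a 2-carboxyethyl chain at this carbon would fall with hydrogen and 2-carbamoylethyl or with 2-(benzyloxycarbonyl)ethyl. Compound 1 differs from the others in more than one place, so it says nothing about this position, and a read-out at one dose tells only of a stronger or weaker effect at that dose.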